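This account rests on a few compounds, and the source may have more. Where it says the series, first, only, none or still open, it means among the compounds named here.

In a functional assay on A20 cells (Mus musculus) for inhibition, with stated times of 1 h, 16 h and 24 h; on this read-out lower numbers stand for stronger inhibition and higher numbers for weaker inhibition:

- compound 1 `N#CCNC(=O)[C@@H]1CC(F)(F)C[C@H]1C(=O)N1CCOCC1`: 925 nM
- compound 2 `N#CC1(NC(=O)[C@@H]2C[C@@H](S(=O)(=O)c3ccccc3)C[C@H]2C(=O)N2CC3CCC(C2)O3)CC1`: 16 nM
- compound 3 `N#CC1(NC(=O)[C@@H]2C[C@@H](S(=O)(=O)c3ccccc3)C[C@H]2C(=O)N2CC3(COC3)C2)CC1`: 248 nM

Compound 3, at 248 nM, holds the middle place among the three numbers. Compound 2 lies lower at 16 nM, and compound 1 lies higher at 925 nM.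

Compound 4 `CN1CCN(C(=O)[C@@H]2C[C@H](S(=O)(=O)c3ccccc3)C[C@H]2C(=O)NC2(C#N)CC2)CC1` keeps the rest of compound 3 and changes one group on a carbonyl carbon, where the 4-methylpiperazin-1-yl group enters: a group of 7 heavy atoms (5 carbon, 2 nitrogen; one six-membered non-aromatic ring with 2 hetero atoms) in place of a group of 7 heavy atoms (5 carbon, 1 nitrogen, 1 oxygen; 2 four-membered non-aromatic rings with 1 hetero atom each), on a carbonyl carbon.

Among the measured compounds shown here, only one measured step bears on this place, a 16-fold higher number from compound 2 to compound 3 (1.19 log units; beyond the scatter), and it is large. It shows that the group on this carbonyl carbon can move the number in this assay well beyond the scatter. For the measured compounds named here, compound 1 differs in more than one place and offers no such step. Going by the values given here, no measured compound carries the 4-methylpiperazin-1-yl group, so the direction is uncertain. Its six-membered ring with two hetero atoms does, however, also occur in the group of compound 2, which gives a weak lean towards lower numbers.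

The expected change is a 3.5-fold lower number from compound 3 to compound 4 (0.55 log units; beyond the scatter), a partial move rather than the full size of the measured step. For compound 4 the estimated value is 70 nM, with an expected range from 15 nM to 300 nM.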

Compound 4, half-maximal inhibitory concentration: 17 nM
Compound 4: the middle estimate sits 4.1-fold (0.61 log units) above what was measured; the range from low to high includes it.
By their numbers in this assay, from the lowest: compounds 2 and 4 (each within the scatter of the next); then compound 3; then compound 1.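

In this assay, the 4-methylpiperazin-1-yl group on this carbonyl carbon gives a 15-fold lower number from compound 3 to compound 4 (1.16 log units; beyond the scatter), so the group at this place moves the number down from compound 3 as well as up, and a group with no oxygen can do so. The same group gives a 1.1-fold higher number from compound 2 to compound 4 (0.03 log units; within the scatter), which lies within the scatter, so among these three compounds the two groups with a six-membered ring containing two hetero atoms stand level, while the group with two four-membered rings in compound 3 stands apart. Nothing at hand explains this difference between the groups.

The compounds shown leave open what the methyl group contributes, as a plain piperazin-1-yl group on the core of compound 4 would be needed to separate it from the ring. They also leave open whether a six-membered ring is enough in itself, which a morpholin-4-yl group or a piperidin-1-yl group on that core could test, or whether an open-chain amine such as dimethylamino would reach the same level.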